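A few compounds are considered here, and "the series" means these few. Any claim that something is new, unique, unknown or untested is made for them only; others in the source may bear on it.

The series shares a core in which an amide-type nitrogen carries a benzyl-like arm and an aryl group. Among the compounds with values here, compound 1 `COC(=O)c1ccc(N(Cc2ccc(C3CCCCC3)cc2)C(=O)[C@H]2CCN2S(=O)(=O)c2c(F)c(F)c(F)c(F)c2F)c(F)c1` is the only member with a number: in a functional assay on MDA-MB-231 cells (Homo sapiens) for antiproliferative activity, with a stated time of 72 h (on this read-out lower numbers stand for an effect already at smaller amounts and higher numbers for an effect only at larger amounts of compound), compound 1 gives 4400 nM. Compound 2 `CONC(=O)c1ccc(N(Cc2ccc(C3CCCCC3)cn2)C(=O)[C@H]2CCN2S(=O)(=O)c2c(F)c(F)c(F)c(F)c2F)c(F)c1` was run in this assay too, where compound 2 gives "not determined" (no result reported), so compound 2 has no single number to stand on; only its structure is known, with a methoxycarbamoyl group and a ring nitrogen in the arm that set it apart from compound 1.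

Compound 3 `O=C([C@H]1CCN1S(=O)(=O)c1c(F)c(F)c(F)c(F)c1F)N(Cc1ccc(C2CCCCC2)cn1)c1ccc2c(=O)[nH]cnc2c1` keeps the arm of compound 2 and changes the aryl group: a group of 11 heavy atoms (8 carbon, 2 nitrogen, 1 oxygen; one six-membered aromatic ring of carbon only, one six-membered aromatic ring with 2 hetero atoms) in place of a group of 12 heavy atoms (8 carbon, 1 nitrogen, 2 oxygen, 1 fluorine; one six-membered aromatic ring of carbon only), on an amide-type nitrogen. Within the data shown here, with no step between measured compounds available, the size and direction of this change cannot be read from the data; the one reference point is compound 1. Compound 3 is therefore expected to lie near that point, with a wide band around it: an estimated 3000 nM, between 500 nM and 20000 nM.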

Compound 3, half-maximal effective concentration: 3300 nM
Estimate against measurement, compound 3: 1.1-fold (0.04 log units) below; the range from low to high includes it.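

No new step can be read from this result: compound 2 has no number to set against compound 3, and compound 1 differs from compound 3 in more than one place. The compounds shown leave open how the change of aryl group on the amide-type nitrogen alone affects activity. No evidence bears on the result.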